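A larger ring in place of cyclopropyl

The source may hold more compounds than are shown below. What is called first, only, known or untested is meant among the compounds shown, and "the series" means these compounds.

Measured in a functional assay on KYSE-410 cells (Homo sapiens) for antiproliferative activity, read by MTT assay, with a stated time of 72 h; on this read-out lower numbers stand for stronger inhibition and higher numbers for weaker inhibition:
- compound 1 `O=C(Nc1cccc(F)c1)c1cc(=O)[nH]c2cc(-c3ccc(F)cc3)ccc12`: 10300 nM
- compound 2 `COc1ccc(-c2ccc3c(C(=O)Nc4cccc(F)c4)cc(=O)[nH]c3c2)cc1`: 18000 nM
- compound 3 `O=C(Nc1cccc(F)c1)c1cc(=O)[nH]c2cc(C3CC3)ccc12`: > 20000 nM

In this assay compound 3 stands at > 20000 nM, which is a limit of the assay and not a number.

Compound 4 `O=C(Nc1cccc(F)c1)c1cc(=O)[nH]c2cc(C3=CCOCC3)ccc12` has not been measured yet. Its difference from compound 3 is a group of 6 heavy atoms (5 carbon, 1 oxygen; one six-membered non-aromatic ring with 1 hetero atom) in place of a group of 3 heavy atoms (3 carbon; one three-membered non-aromatic ring of carbon only), on an aromatic carbon.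

Within the data shown here, the steps that bear on this change are those that replace the group at this same aromatic carbon. They are an at least 1.9-fold higher number from compound 1 to compound 3 (0.28 log units; that floor lies within the scatter) and an at least 1.1-fold higher number from compound 2 to compound 3 (0.04 log units; that floor lies within the scatter), and the floor of each lies within the scatter. The change of methoxy for fluoro, a 1.7-fold higher number from compound 1 to compound 2 (0.24 log units; within the scatter), also stays within the scatter.

So no measured change at this place goes beyond the scatter, and no step beyond the scatter is expected here, in either direction. The estimated step is an at least 1.2-fold lower number from compound 3 to compound 4 (0.09 log units; that floor lies within the scatter).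

For compound 4 the expected value is 16000 nM, with an estimated range from 8000 nM to 30000 nM.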

Compound 4, half-maximal inhibitory concentration: 12100 nM
Estimate against measurement, compound 4: 1.3-fold (0.12 log units) above, and the stated range covers the measured number.
By their numbers in this assay, from the lowest: compounds 1, 4 and 2 (each within the scatter of the next). At a limit, above all of these: compound 3.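

In this assay, compound 4 gives the first actual number, and not a limit, for a non-aromatic ring on this aromatic carbon. An aromatic ring is therefore not required here for a number in this range: the two comparisons with aromatic groups are a 1.5-fold lower number from compound 2 to compound 4 (0.17 log units; within the scatter) and a 1.2-fold higher number from compound 1 to compound 4 (0.07 log units; within the scatter). The comparison with cyclopropyl, an at least 1.6-fold lower number from compound 3 to compound 4 (0.21 log units; that floor lies within the scatter), gives only a floor, and its true size stays unknown: the limit of > 20000 nM in this assay, at which 1 of the 4 values shown sits.

From the compounds shown here alone, it remains open whether any group on this carbon can move the number beyond the scatter, and whether the oxygen or the double bond of the new ring matters at all. Going by these compounds, how a saturated piperidine ring, a simple amine or a carboxylic acid would read at this place also stays open.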